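The source may report more compounds than this note shows. Statements on the series, on what has been measured and on what is new or still open speak of the compounds shown alone.

Of the compounds shown here, three built on one shared core have been measured, and one more awaits. Compound 1 `CC(C)CCn1cnc2c(NCc3cccc(Cl)c3)nc(N[C@H]3CC[C@H](N)CC3)nc21` gives 16700 nM in a functional assay on HCC827 cells (Homo sapiens) for inhibition, read by fluorescence, with a stated time of 72 h; a higher number here means a weaker inhibitor of growth, a lower number a stronger inhibitor of growth. Compound 2 `CC(C)CCn1cnc2c(Nc3cccc(O)c3)nc(N[C@H]3CC[C@H](N)CC3)nc21` gives 21300 nM in this assay, and compound 3 `CC(C)CCn1cnc2c(Nc3ccccc3)nc(N[C@H]3CC[C@H](N)CC3)nc21` gives 21700 nM. Compound 3 has the highest of the three numbers, yet a 1.3-fold higher number from compound 1 to compound 3 (0.11 log units; within the scatter) and a 1.0-fold higher number from compound 2 to compound 3 (0.01 log units; within the scatter) are both within the scatter, as is a 1.3-fold higher number from compound 1 to compound 2 (0.11 log units; within the scatter), so the three compounds cannot be told apart on these numbers.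

Compound 4 `CCCCn1cnc2c(Nc3ccccc3)nc(N[C@H]3CC[C@H](N)CC3)nc21` is the unmeasured one. It differs from compound 3 only on the side chain: hydrogen in place of methyl on a saturated chain carbon bound to two saturated chain carbons. Among the measured compounds shown here, none of the measured steps touches that chain; all of them alter the group on the nitrogen of the aromatic ring, and all stayed within the scatter. There is thus nothing in the measured data that points to a step in either direction here, and the expectation is a step no larger than the scatter, a 1.0-fold higher number from compound 3 to compound 4 (0.01 log units; within the scatter). Compound 4 is therefore estimated at 22000 nM, within a range from 8000 nM to 60000 nM.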

Compound 4, concentration for 50% growth inhibition: 9000 nM
Estimate against measurement, compound 4: 2.4-fold (0.39 log units) above; the measured number falls inside the stated range.
By their numbers in this assay, from the lowest: compounds 4, 1, 2 and 3 (each within the scatter of the next, the first and the last beyond it).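

In this assay, hydrogen in place of methyl on a saturated chain carbon bound to two saturated chain carbons, which turns isopentyl into butyl, gives a 2.4-fold lower number from compound 3 to compound 4 (0.38 log units; beyond the scatter) and is a modest step, but the only one shown that lies beyond the scatter. The side chain, untouched by the earlier comparisons, can therefore move the number, whereas the changes shown to the group on a nitrogen on an aromatic ring all stayed within the scatter. No measurement shown accounts for this step.

From the compounds shown here alone, whether a shorter chain such as propyl, a longer chain such as hexyl, or a chain ending in an amine would continue this shift remains open. So does whether butyl would give a similar step alongside 3-chlorobenzyl or 3-hydroxyphenyl.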